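Methyl addition on an inactive alkyne pair

This account rests on a few compounds, and the source may have more. Where it says the series, first, only, none or still open, it means among the compounds named here.

Measured compounds:
compound 1 `CCNc1ncc(C#Cc2ccc(C)cc2)cn1`: "not active" (no number reported)
compound 2 `CC(C)(C)c1ncc(C#Cc2ccccc2)cn1`: 247000 nM
compound 3 `Cc1ncc(C#Cc2ccccc2)cn1`: "not active" (no number reported)

In an assay on HEK293 cells for positive allosteric modulation of metabotropic glutamate receptor 5 (Rattus norvegicus) (on this read-out higher numbers stand for an effect only at larger amounts of compound and lower numbers for an effect already at smaller amounts), compound 3 gives "not active" (no number reported), so it stands without a number at all; compound 1 likewise gives "not active" (no number reported). Only compound 2 returns a figure, 247000 nM, and that figure lies at very high concentration. Compound 4 `Cc1ccc(C#Cc2cnc(C)nc2)cc1` is compound 3 with one change, (methyl in place of hydrogen on an aromatic carbon). Among the measured compounds shown here, no comparable step between measured compounds exists. Compound 1 carries the same methyl on the carbon-only ring and shows no activity, so no shift beyond the scatter in this assay is expected from this change, and in either direction. If compound 4 does yield a number at all, it is estimated at 300000 nM, within 100000 nM to 1000000 nM.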

Compound 4, half-maximal effective concentration: "not active" (no number reported)
For compound 4 the study gives words and no number; no gap can be computed for the estimate.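

Compound 3 gives "not active" (no number reported) and compound 4 gives "not active" (no number reported) so no step can be read for this methyl. No supporting data bear on the result. Going by these compounds, whether this methyl changes activity where a compound returns a number stays open.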